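The compounds below may be only part of what the source reports. "The series", "measured", "known", "first", "only" and "open" are said of these compounds alone.

Working notes on the series. Compound 1 `Cc1nc(N)c2nc(-c3ccccc3)sc2n1` gives 34 nM in an assay on CHO cells for displacement of a labelled ligand from adenosine receptor A1 (Homo sapiens), read by scintillation counting, with a stated time of 3 h; on this read-out higher numbers stand for weaker inhibition and lower numbers for stronger inhibition. Compound 2 `N#Cc1cccc(-c2nc(N)c3nc(-c4ccco4)sc3n2)c1` gives 103 nM in this assay. Compound 3 `Cc1nc(NC(=O)c2ccccc2)c2nc(-c3ccccc3)sc2n1` gives 935 nM in this assay, the highest of the three numbers, with compound 2 the nearest of the other two. Among the measured compounds shown here, the one step with both ends measured is a 28-fold higher number from compound 1 to compound 3 (1.44 log units; beyond the scatter), benzoyl in place of hydrogen on a nitrogen on an aromatic ring, and it is large.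

Compound 4 `Cc1nc(NC(=O)c2ccc(Cl)cc2)c2nc(-c3ccccc3)sc2n1` is not yet measured. From compound 3 it differs by chloro in place of hydrogen on an aromatic carbon, the chlorine sitting on an aromatic carbon of a six-membered aromatic ring of carbon only, so that the benzoyl group becomes a 4-chlorobenzoyl group. For the measured compounds named here, no measured step touches a substituent on this ring: the only step with numbers changes the amide itself, not a halogen on the benzoyl ring, so it does not speak to the present change. With nothing in the data bearing on this exact substitution, the expected step is a 1.0-fold lower number from compound 3 to compound 4 (0.02 log units; within the scatter), within the scatter. Going by the values given here, compound 4 is therefore estimated at 900 nM in this assay, with a range from 300 nM to 2800 nM, kept wide since no analogue carries this chlorine.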

Compound 4, inhibition constant: > 30000 nM
Compound 4 ended at the assay's limit; the forecaster's own chance of this, stated with the estimate: 5%; middle value at least 33-fold (1.52 log units) from the limit.
By their numbers in this assay, from the lowest: compound 1; then compound 2; then compound 3. At a limit, above all of these: compound 4.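

Compound 4 stands at a limit of this assay, not at a number: the limit of > 30000 nM in this assay, at which 1 of the 4 values shown sits. Chloro in place of hydrogen on an aromatic carbon, para to a large group, gives an at least 32-fold higher number from compound 3 to compound 4 (1.50 log units; beyond the scatter), so the benzoyl ring of this series is not indifferent to substitution, and a single added heavy atom at this place is enough to reach the limit. Among the compounds shown here, until now the only step with both ends measured was a 28-fold higher number from compound 1 to compound 3 (1.44 log units; beyond the scatter), which concerns the amide nitrogen and says nothing about the benzoyl ring; the new step is also large, with the amide left unchanged.

The compounds shown leave open whether this result belongs to chlorine itself or to any group at this place, and a fluoro, a methoxy or an amine in the same position would separate those two readings. They also leave open whether chloro elsewhere on the benzoyl ring, or on the phenyl group of the shared core, gives a step of this size.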